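Chloro for hydrogen on the aryl of compound 3

The compounds below may be only part of what the source reports. "The series", "measured", "known", "first", "only" and "open" are said of these compounds alone.

Measured so far:
compound 1 `COc1ccc(-c2nc(C)c(C(=O)CSc3nc(-c4ccc(Cl)cc4)c(C#N)c(=O)[nH]3)s2)cc1`: 92.7%
compound 2 `Cc1nc(-c2ccccc2)sc1C(=O)CSc1nc(-c2cccc(Cl)c2)c(C#N)c(=O)[nH]1`: 83.7%
compound 3 `Cc1nc(-c2ccccc2)sc1C(=O)CSc1nc(-c2ccccc2)c(C#N)c(=O)[nH]1`: 87.5%

In a functional assay on U-87MG ATCC cells for antiproliferative activity against U-87 MG (Homo sapiens), read by MTT assay, with a stated time of 48 h, tested at 10 uM (on this read-out lower numbers stand for a stronger effect and higher numbers for a weaker effect at the one concentration tested), compound 3 gives 87.5%, the second highest of the three numbers; its neighbours are compound 2 with 83.7% and compound 1 with 92.7%, both within the scatter of compound 3, so no order among the three can be read from these numbers.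

Compound 4 `Cc1nc(-c2ccccc2)sc1C(=O)CSc1nc(-c2ccc(Cl)cc2)c(C#N)c(=O)[nH]1` is not yet measured. Its difference from compound 3 is chloro in place of hydrogen on an aromatic carbon.

Among the compounds with values here, only one measured step bears on this change, and it runs the other way: a number 3.8 percentage points higher from compound 2 to compound 3 (within the scatter), that is, removing a chloro from an aromatic carbon left the read-out essentially unchanged. Compound 1, which also carries a 4-chlorophenyl but differs from compound 4 elsewhere as well, sits within the scatter of compound 3. Adding the chloro in compound 4 is therefore expected to give no step beyond the scatter, a number 1.5 percentage points higher from compound 3 to compound 4 (within the scatter).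

Compound 4 is estimated at 89%, expected between 77% and 99%.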

Compound 4, a percentage reported as activity, at one concentration (the size of the read-out at that concentration, not a potency): 85.2%
The estimate for compound 4 lay 3.8 percentage points above the measured number; low and high end bracket the measured number.
By their numbers in this assay, from the lowest: compounds 2, 4, 3 and 1 (each within the scatter of the next).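

In this assay, chloro in place of hydrogen at this position now has its own direct step, a number 2.3 percentage points lower from compound 3 to compound 4 (within the scatter), and the change of 3-chlorophenyl to 4-chlorophenyl gives a number 1.5 percentage points higher from compound 2 to compound 4 (within the scatter), so phenyl, 3-chlorophenyl and 4-chlorophenyl are not told apart on this read-out. Hydrogen in place of methoxy on the other aromatic ring, a number 7.5 percentage points lower from compound 1 to compound 4 (within the scatter), also stays within the scatter, so neither place has yet produced a separable step among these compounds. No measurement is at hand that bears on the origin of these small steps.

Still open, from the compounds shown here alone, is whether an amine or a carboxylic acid on the same aromatic carbon would give a step beyond the scatter. The same question stands for a morpholine ring or a longer alkyl chain at the methoxy place.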